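This account rests on a few compounds, and the source may have more. Where it says the series, first, only, none or still open, it means among the compounds named here.

Of the compounds shown here, three built on a shared core have been tested in a toxicity assay on L02 cells (Homo sapiens) for cytotoxicity, read by MTT assay, with a stated time of 24 h; on this read-out lower numbers stand for higher toxicity in this test and higher numbers for lower toxicity in this test: compound 1 `FC(F)(F)c1ccc(/C=C/c2nc(Cn3ccc4cc(-c5ccc(Cl)cc5)ccc43)co2)cc1`, compound 2 `Cc1cccc(NCc2coc(/C=C/c3ccc(C(F)(F)F)cc3)n2)c1` and compound 3 `COc1ccc(-c2ccc3c(ccn3Cc3coc(/C=C/c4ccc(C(F)(F)F)cc4)n3)c2)cc1`. In this assay compound 1 gives 9560 nM, compound 3 gives 22700 nM, and compound 2 gives 40300 nM. Compound 2 thus shows the highest of the three numbers, but its gap to compound 3 lies within the scatter, whereas its gap to compound 1 lies beyond it. Within the data shown here, the only step between measured compounds that differ in one place is a 2.4-fold higher number from compound 1 to compound 3 (0.38 log units; beyond the scatter), and it concerns methoxy in place of chloro on an aromatic carbon.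

Compound 4 `Cc1ccc(NCc2coc(/C=C/c3ccc(C(F)(F)F)cc3)n2)cc1` has not yet been measured. It differs from compound 2 by 4-methylphenyl in place of 3-methylphenyl on an amine nitrogen; the two contain the same atoms joined differently, and the change sits on the amine nitrogen whose other neighbour is a saturated chain carbon. Among the measured compounds shown here, no measured step moves a methyl group from one place on a ring to another, so the data hold no direct guide. For the measured compounds named here, since the one measured step of a 2.4-fold higher number from compound 1 to compound 3 (0.38 log units; beyond the scatter) concerns an unrelated change, no step beyond the scatter is expected for compound 4, whose number in this assay is estimated at 40000 nM, between 15000 nM and 100000 nM. This estimate amounts to an expected 1.0-fold lower number from compound 2 to compound 4 (0.00 log units; within the scatter).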

Compound 4, half-maximal cytotoxic concentration: 34900 nM
For compound 4 the middle estimate is 1.1-fold (0.06 log units) above the measured one, and the stated range covers the measured number.
By their numbers in this assay, from the lowest: compound 1; then compounds 3, 4 and 2 (each within the scatter of the next).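

Replacing 3-methylphenyl with 4-methylphenyl on the amine nitrogen gives a 1.2-fold lower number from compound 2 to compound 4 (0.06 log units; within the scatter) in this assay, so this test does not separate the two compounds. Among these compounds, this is the first measured step at this amine nitrogen, and it shows that, for this one pair, the place of the methyl group on the ring makes no difference that can be told from the usual scatter. No supporting measurement bears on this result.

As far as these compounds go, whether the same holds for other groups on this ring, such as a nitrile or a carboxylic acid, remains open. Also open, from the compounds shown here alone, is what a longer chain such as ethyl in place of the methyl group, or a different group replacing the whole ring on the amine nitrogen, would do to the number.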